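Replacing a phenoxy group with 4-fluorophenyl on the pyrazole series

The source may hold more compounds than are shown below. What is called first, only, known or untested is meant among the compounds shown, and "the series" means these compounds.

Measured compounds:
compound 1, `Cc1n[nH]c(C(=O)O)c1Cc1cccc(-c2ccc(C#N)cc2)c1`, 46%
compound 2, `Cc1n[nH]c(C(=O)O)c1Cc1ccc(-c2ccc(OC(F)(F)F)cc2)cc1`, 29%
compound 3, `Cc1n[nH]c(C(=O)O)c1Cc1ccccc1Oc1ccccc1`, 49%

The three compounds share one core and differ only in the aryl group attached to the benzyl ring. In an assay on isolated protein for inhibition of 2-Hydroxyacid oxidase 2 (Homo sapiens), tested at 10 uM (a higher number here means a stronger effect of the compound at the concentration tested, a lower number a weaker effect), compound 3 gives the highest of the three numbers, but compound 1 sits close enough that the two cannot be told apart within the usual scatter. Compound 2 lies further down, and its gap to compound 3 is beyond the scatter.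

Compound 4, `Cc1n[nH]c(C(=O)O)c1Cc1ccccc1-c1ccc(F)cc1`, is not yet measured. It differs from compound 3 by 4-fluorophenyl in place of phenoxy on an aromatic carbon. Among the compounds with values here, no step between measured compounds shows this change directly, so the expectation rests on the spread of the three numbers seen. Given that compounds 1 and 3 stand within the scatter of each other, a modest step is expected, a number 7 percentage points lower from compound 3 to compound 4 (within the scatter), with no clear direction beyond the scatter. In this assay compound 4 is estimated at 42%, with a range from 22% to 62%.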

Compound 4, a percentage reported as inhibition, at one concentration (the size of the read-out at that concentration, not a potency): 56%
The estimate for compound 4 lay 14 percentage points below the measured number, within the range that was stated.
By their numbers in this assay, from the lowest: compound 2; then compounds 1, 3 and 4 (each within the scatter of the next).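

In this assay, exchanging phenoxy for 4-fluorophenyl on this aromatic carbon, ortho to a large group, gives a number 7 percentage points higher from compound 3 to compound 4 (within the scatter), the only direct step at this position among the compounds shown. The exchange removes the oxygen of phenoxy and the hydrogen-bond acceptor counted for that group, yet the number does not move beyond the scatter, so neither is shown to be required to keep the read-out at this position. No measured evidence accounts for this result.

The compounds shown leave open what the fluorine itself contributes, and whether an unsubstituted phenyl, a methoxy group or an amine on the same carbon would hold the number. Going by these compounds, the read-outs also come from a single concentration, so how the potencies of compound 3 and compound 4 compare remains unknown.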